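The source may hold more compounds than are shown below. What is called first, only, known or untested is meant among the compounds shown, and "the series" means these compounds.

Measured in a functional assay on cells (Platelet, Homo sapiens) for inhibition; a lower number here means a stronger inhibitor, a higher number a weaker inhibitor:
- Compound 1 `CCOC(=O)c1ccc(-c2nn(Cc3ccccc3Cl)c3ccccc23)cc1`: 230 nM
- Compound 2 `CCOC(=O)c1ccc(-c2nn(C(C)C)c3ccccc23)cc1`: 650 nM
- Compound 3 `NC(=O)c1ccc(-c2nn(Cc3ccccc3)c3ccccc23)cc1`: > 10000 nM, a limit of the assay

Going by the values given here, compound 3 gives no number, only a limit, and it is the one compound of the three that stands there: the limit of > 10000 nM in this assay, at which 1 of the 3 values shown sits. Compound 4 `CC(C)NC(=O)c1ccc(-c2nn(Cc3ccccc3)c3ccccc23)cc1` is built from compound 3 by one change, (isopropyl in place of hydrogen on an amide-type nitrogen), with isopropyl in place of hydrogen on an amide-type nitrogen. Among the compounds with values here, no measured step touches that nitrogen. Within the data shown here, the only measured step, a 2.8-fold higher number from compound 1 to compound 2 (0.45 log units; beyond the scatter), swaps isopropyl for 2-chlorobenzyl on an aromatic nitrogen, a different place, so it offers no more than a rough size for what a single change does in this assay. On that basis a modest move toward a lower number is expected, and compound 4 may well remain at the limit. The expected step is an at least 1.6-fold lower number from compound 3 to compound 4 (0.22 log units; that floor lies within the scatter). The estimate for compound 4 is 6000 nM, with an expected range of 1500 nM to 20000 nM.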

Compound 4, half-maximal inhibitory concentration: > 10000 nM
Compound 4 was reported as a limit; the forecaster's own chance of this, stated with the estimate: 60%; at least 1.6-fold (0.22 log units) between middle value and limit.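

Going by these compounds alone, compound 3 and compound 4 are both reported only as limits in this assay, so no step between them can be read. The compounds shown leave open how far, if at all, isopropyl in place of hydrogen on an amide-type nitrogen shifts inhibition, and the values reach only this: the limit of > 10000 nM in this assay, at which 2 of the 4 values shown sit.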